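Bromo for nitro at the limit of the assay

The source may hold more compounds than are shown below. What is called first, only, known or untested is meant among the compounds shown, and "the series" means these compounds.

Compound 1 `NC(=S)N1N=C(c2ccc(N3CCCCC3)cc2)CC1c1ccc(Cl)cc1`: 22300 nM
Compound 2 `O=[N+]([O-])c1ccc(-c2csc(N3N=C(c4ccc(N5CCCCC5)cc4)CC3c3ccc(Cl)cc3)n2)cc1`: > 100000 nM (a limit)
Compound 3 `Clc1ccc(-c2csc(N3N=C(c4ccc(N5CCCCC5)cc4)CC3c3ccc(Cl)cc3)n2)cc1`: > 100000 nM (a limit)

In a functional assay on MCF7 cells (Homo sapiens) for antiproliferative activity, read by MTT assay, with a stated time of 72 h (a higher number here means a weaker inhibitor, a lower number a stronger inhibitor), compound 2 gives > 100000 nM as a limit, not a number. Compound 3 also gives > 100000 nM as a limit. The two therefore share one reading (the limit of > 100000 nM in this assay, at which 2 of the 3 values shown sit), and only compound 1 has a number (22300 nM).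

Compound 4 `Clc1ccc(C2CC(c3ccc(N4CCCCC4)cc3)=NN2c2nc(-c3ccc(Br)cc3)cs2)cc1` has not been measured. It differs from compound 2 by bromo in place of nitro on an aromatic carbon. Among the measured compounds shown here, the closest measured step is chloro in place of nitro (a step that the two limits leave unreadable from compound 2 to compound 3), and it shows only that both compounds remain at the limit. The other measured step (an at least 4.4-fold higher number from compound 1 to compound 3 (0.65 log units; beyond the scatter)) lies beyond the scatter and goes to a higher number when the small group on the ring amine nitrogen gives way to a large one. Compound 4 carries a large group of that kind, with bromo in place of chloro.

No step beyond the scatter is therefore expected in this assay, and the estimated step (a number no higher from compound 2 to compound 4 (the limit leaves the size open)) reflects this. Compound 4 is estimated at 100000 nM in a range from 35000 nM to 250000 nM and is expected to be reported most likely as a limit.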

Compound 4, half-maximal inhibitory concentration: > 100000 nM
Compound 4 ended at the assay's limit; the forecaster's own chance of this, stated with the estimate: 75%; the middle value sits exactly at the limit.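

Compound 4 places a third group, bromo, on the aromatic carbon para to a large group, and in this assay its reading of > 100000 nM is again a limit and not a number. The steps among compound 2, compound 3 and compound 4 cannot be read, so nitro, chloro and bromo cannot be ranked at this position, and none of the three gives a number: the limit of > 100000 nM in this assay, at which 3 of the 4 values shown sit.

Among the compounds shown here, the one readable step is an at least 4.4-fold higher number from compound 1 to compound 4 (0.65 log units; beyond the scatter), so the large group on the ring amine nitrogen goes to a higher number with bromo as it does with chloro.

On these data alone, how far beyond the limit any of these three compounds lies stays open, and with it whether the change from nitro to a halogen has any effect at all in this assay. Also open, as far as these compounds go, is whether an amine or a carboxylic acid on that aromatic carbon would bring the reading back to a number, or whether only the group on the ring amine nitrogen decides this.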